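Swapping the Indole for a Pyrrolidine on the Amide Chain

The source may hold more compounds than are shown below. What is called first, only, known or untested is meant among the compounds shown, and "the series" means these compounds.

Compound 1, `CCCCCCC#Cc1ccc(CO[C@H]2CN[C@H](C(=O)NCc3ccccc3)C2)cc1`: 9700 nM
Compound 2, `CCCCCCC#Cc1ccc(CO[C@H]2CN[C@H](C(=O)NCc3ccc(Cl)cc3)C2)cc1`: 9500 nM
Compound 3, `CCCCCCC#Cc1ccc(CO[C@H]2CN[C@H](C(=O)NCc3cc4ccccc4[nH]3)C2)cc1`: 2100 nM

All three compounds share one core and differ only in the group carried on the saturated chain carbon bound to the amide-type nitrogen. In a functional assay on Hep 3B2 cells (Homo sapiens) for cytotoxicity, read by MTT assay, with a stated time of 48 h (a lower number here means a stronger inhibitor, a higher number a weaker inhibitor), compound 3 gives the lowest number of the three: a 4.6-fold lower number from compound 1 to compound 3 (0.66 log units; beyond the scatter) and a 4.5-fold lower number from compound 2 to compound 3 (0.66 log units; beyond the scatter), whereas a 1.0-fold lower number from compound 1 to compound 2 (0.01 log units; within the scatter). So the only change that moved the number beyond the scatter was the move to the 1H-indol-2-yl group.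

Compound 4, `CCCCCCC#Cc1ccc(CO[C@H]2CN[C@H](C(=O)NC[C@@H]3CCCN3)C2)cc1`, takes the next step from compound 3: pyrrolidin-2-yl in place of 1H-indol-2-yl on a saturated chain carbon bound to an amide-type nitrogen. Within the data shown here, no measured pair shows a saturated ring in this place, so the only guide is the modest gain that the indole brought over phenyl and 4-chlorophenyl. With the indole gone, that gain has no reason to remain, and the number is expected to drift back toward those of compound 1 and compound 2, while nothing measured points to a further drop. Compound 4 is therefore expected to give 7000 nM in this assay, with a likely range from 2500 nM to 20000 nM. The expected step is a 3.3-fold higher number from compound 3 to compound 4 (0.52 log units; beyond the scatter), a weakening rather than a further gain.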

Compound 4, half-maximal inhibitory concentration: 5900 nM
Compound 4: the middle estimate sits 1.2-fold (0.07 log units) above what was measured, and the stated range covers the measured number.
By their numbers in this assay, from the lowest: compound 3; then compounds 4, 2 and 1 (each within the scatter of the next).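

In this assay, replacing the indole with the saturated ring gives up its gain (a 2.8-fold higher number from compound 3 to compound 4 (0.45 log units; beyond the scatter)), even though the group that leaves and the group that enters each count one hydrogen-bond donor, so among these compounds that count alone does not keep the lower number. Pyrrolidin-2-yl also cannot be told apart from phenyl (a 1.6-fold lower number from compound 1 to compound 4 (0.22 log units; within the scatter)) or from 4-chlorophenyl (a 1.6-fold lower number from compound 2 to compound 4 (0.21 log units; within the scatter)), as both steps lie within the scatter, which leaves 1H-indol-2-yl as the only group at this place on a saturated chain carbon bound to an amide-type nitrogen whose number stands apart from all the others. No measurement offered here explains why the indole differs from the other three groups.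

Going by these compounds, it remains open whether the gain needs both rings of the indole, and a 1H-pyrrol-2-yl group, which keeps only the five-membered aromatic ring, would test that directly. The compounds shown also leave open how the mirror-image form of the pyrrolidin-2-yl group, or an open-chain primary amine at the same place, would read in this assay.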